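Lengthening the amine-bearing chain and closing the amine into a ring

The source may report more compounds than this note shows. Statements on the series, on what has been measured and on what is new or still open speak of the compounds shown alone.

Measured so far:
compound 2, `CCN(CC)CCCCCCCCOc1ccc(/C=C/C(=O)Nc2ccccc2)cc1OC`: 1.75
compound 1, `CCN(CC)CCCCOc1ccc(/C=C/C(=O)Nc2ccccc2)cc1OC`: 1.59

Of the compounds shown here, two sharing one core have been measured in a physicochemical assay for lipophilicity, using the shake flask method, measured as octanol-water partition, at pH 7.4; a lower number here means a more polar compound, a higher number a more lipophilic compound. Compound 1, `CCN(CC)CCCCOc1ccc(/C=C/C(=O)Nc2ccccc2)cc1OC`, gives 1.59. Compound 2, `CCN(CC)CCCCCCCCOc1ccc(/C=C/C(=O)Nc2ccccc2)cc1OC`, gives 1.75, which is the higher of the two numbers, though the gap to compound 1 is within the scatter: a number 0.16 log units higher from compound 1 to compound 2 (within the scatter).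

Compound 3, `COc1cc(/C=C/C(=O)Nc2ccccc2)ccc1OCCCCCCCCCCN1CCCCC1`, has not yet been measured. Its difference from compound 2 is 2-(piperidin-1-yl)ethyl in place of diethylamino on a saturated chain carbon, eight bonds along the chain from an oxygen on an aromatic ring. Among the compounds with values here, the only measured step that bears on it is the one from compound 1 to compound 2, where four additional chain carbons changed the reading hardly at all, a number 0.16 log units higher from compound 1 to compound 2 (within the scatter). The change to compound 3 adds fewer chain atoms than that step did but also replaces the open diethylamino group with a six-membered ring. On this basis compound 3 is expected to read a little higher than compound 2, by about a number 0.30 log units higher from compound 2 to compound 3 (within the scatter), a step that may well stay within the scatter. The estimate for compound 3 in this assay is therefore 2.05, with a likely range from 1.6 to 2.6.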

Compound 3, partition coefficient: 1.83
Compound 3: middle estimate off by 0.22 log units, on the high side; measured number inside the range.
By their numbers in this assay, from the lowest: compounds 1, 2 and 3 (each within the scatter of the next).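

In this assay, 2-(piperidin-1-yl)ethyl in place of diethylamino gives a number 0.08 log units higher from compound 2 to compound 3 (within the scatter), which shows that this change at the end of the chain, bringing in one six-membered non-aromatic ring with 1 hetero atom, does not move the reading beyond what repeated measurements would scatter. The wider comparison, 6-(piperidin-1-yl)hexyl in place of diethylamino on a saturated chain carbon, four bonds along the chain from an oxygen on an aromatic ring, gives a number 0.24 log units higher from compound 1 to compound 3 (within the scatter), so even the chain extension and the ring closure taken together stay within the scatter, which the earlier pair, with its open diethylamino group at both ends of the step, could not show. Nothing measured here gives a reason for this outcome.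

In compound 3 the ring and the extra chain atoms arrive together, so the compounds shown leave open what the piperidine ring does alone on the chain of compound 1 or compound 2. Also open, from the compounds shown here alone, is whether a morpholine ring, a primary amine or a carboxylic acid at the chain end would carry the reading beyond the scatter.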